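This account rests on a few compounds, and the source may have more. Where it says the series, first, only, none or still open, it means among the compounds named here.

Of the compounds shown here, three that share one core have been tested in a functional assay on YAC-1 cells (Mus musculus) for activation; on this read-out lower numbers stand for an effect already at smaller amounts and higher numbers for an effect only at larger amounts of compound. Compound 1 `Nc1nc(O)c2c(n1)n(C1OC(CO)[C@@H](O)[C@H]1O)c(=O)n2Cc1ccc(Cl)cc1` gives 180 uM in this assay. Compound 2 `C=CCn1c(=O)n(CCCC)c2nc(N)nc(O)c21` gives 4 uM, and compound 3 `C=CCn1c(=S)n(C2OC(COC(C)=O)[C@H]3OC(C)(C)O[C@@H]23)c2nc(N)nc(O)c21` gives 30 uM. Among these three numbers compound 1 stands highest, meaning it needs the largest amount of compound to reach its effect; the nearest number is that of compound 3, separated from compound 1 by a gap beyond the usual scatter, and the furthest is that of compound 2, separated by a much wider gap that is also beyond the scatter. Going by the values given here, none of the measured compounds differ from one another in a single place, so no step between measured compounds is available to lean on.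

Compound 4 `Nc1nc(O)c2c(n1)n(C1OC(CO)[C@@H](O)[C@H]1O)c(=O)n2Cc1ccc([N+](=O)[O-])cc1` differs from compound 1 in one place: nitro in place of chloro on an aromatic carbon. Among the compounds with values here, nothing among the measured compounds shows what such a change does in this assay, and the rest of compound 4 is unchanged from compound 1. The expected step is therefore small and of uncertain direction: a 1.2-fold lower number from compound 1 to compound 4 (0.08 log units; within the scatter), within the usual scatter. Compound 4 is expected to give about 150 uM, with a range from 50 uM to 400 uM.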

Compound 4, concentration for half-maximal effect: 48 uM
Compound 4: the middle estimate sits 3.1-fold (0.49 log units) above what was measured, outside the stated range (below it).
By their numbers in this assay, from the lowest: compound 2; then compounds 3 and 4 (each within the scatter of the next); then compound 1.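

In this assay, replacing 4-chlorobenzyl with 4-nitrobenzyl gives a 3.8-fold lower number from compound 1 to compound 4 (0.57 log units; beyond the scatter), a modest step, but the first one here that isolates a single change. It shows that the read-out responds to what sits on this aromatic carbon, para to a large group, even though the rest of the molecule stays the same; compounds 1, 2 and 3 differ in more than one place, so they could not show this. The swap alters several things at once, including the heavy atoms, the hydrogen-bond acceptors and the double bonds outside aromatic rings, and no available measurement separates these or explains the lower number.

Going by these compounds, whether an amine, a carboxylic acid or a plain hydrogen on the same aromatic carbon would lower the number further, raise it or leave it unchanged stays open, so this single pair gives a direction but no trend. Also open, on these data alone, is whether nitro in place of chloro would give a similar step on a different molecule, since compound 2 and compound 3 carry no such benzyl group.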